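The compounds below may be only part of what the source reports. "The series", "measured", "known", "first", "only" and "open" are said of these compounds alone.

Measured in an ADME assay on J774.1 cells (Mus musculus) for cytotoxicity, read by resazurin assay, with a stated time of 48 h; a higher number here means a weaker inhibitor, a lower number a stronger inhibitor:
- compound 1 `CCCn1cc(C(=O)NCc2ccccc2)c(=O)c2cc(F)c(N3CCC(C(N)=O)CC3)cc21`: 43700 nM
- compound 2 `NC(=O)C1CCN(c2cc3c(cc2F)c(=O)c(C(=O)NCc2ccccc2)cn3C2CC2)CC1`: 51200 nM

Going by the values given here, compound 2 stands level with compound 1, the only other measured compound, as the numbers show a 1.2-fold higher number from compound 1 to compound 2 (0.07 log units; within the scatter). Compound 3 `NC(=O)C1CCN(c2cc3c(cc2F)c(=O)c(C(=O)O)cn3C2CC2)CC1` differs from compound 2 in another place: hydroxy in place of benzylamino on a carbonyl carbon. In words, this is hydroxy in place of benzylamino on a carbonyl carbon, or benzylcarbamoyl to carboxy. Among the compounds with values here, the one measured step concerns only cyclopropyl in place of propyl on an aromatic nitrogen, so it does not test this change. The expectation therefore starts from compound 2 at 51200 nM and rests on judgement, with a wide margin. In this assay, the expected outcome is a moderately higher number, a 1.8-fold higher number from compound 2 to compound 3 (0.24 log units; within the scatter). The estimate for compound 3 is 90000 nM, with an expected range from 35000 nM to 220000 nM.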

Compound 3, half-maximal inhibitory concentration: > 100000 nM
Compound 3 ended at the assay's limit; the forecaster's own chance of this, stated with the estimate: 35%; at least 1.1-fold (0.04 log units) between middle value and limit.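

Going by these compounds alone, until now the only measured change was on the aromatic nitrogen, so compound 3 gives the first look at the carbonyl carbon, where hydroxy replaces benzylamino and the six-membered aromatic ring leaves with it. In this assay compound 3 gives > 100000 nM, which is a limit of the assay and not a number. As a step this reads an at least 1.9-fold higher number from compound 2 to compound 3 (0.29 log units; that floor lies within the scatter), so only a floor is known, and that floor does not show a real change from removing the benzylamino group.

On these data alone, the true size of this step stays unknown. Also open, as far as these compounds go, is whether a smaller methylamino group or a longer phenethylamino chain on the same carbonyl carbon would read like compound 2 or like compound 3.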